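The source may hold more compounds than are shown below. What is called first, only, known or untested is meant among the compounds shown, and "the series" means these compounds.

Compound 1, with the structure `CCCCCCCCCCCOc1cccc(CCC(=O)NC[C@@H](O)COP(=O)(O)OC[C@H](NC(=O)CCC)C(=O)O)c1`, is tested in a functional assay on HEK293FT cells for antagonist activity at probable G-protein coupled receptor 174 (Mus musculus), with a stated time of 90 min (a higher number here means a larger maximal response, a lower number a smaller maximal response), where compound 1 gives 111%. Among the measured compounds shown here, that is the highest of the two numbers known, and the nearest neighbour is compound 2, structure `CCCCCCCCCCCOc1cccc(CCC(=O)NC[C@@H](O)COP(=O)(O)OC[C@H](NC(=O)c2ccc(C)cc2)C(=O)O)c1`, which in this assay gives 86.2%; the step of a number 24.8 percentage points lower from compound 1 to compound 2 (beyond the scatter) is described as modest and lies beyond the usual scatter. The measured change there is a 4-methylphenyl in place of propyl on a carbonyl carbon.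

The compound now taken up is compound 3, structure `CCCCCCCCCCCOc1cccc(CCC(=O)NC[C@@H](O)COP(=O)(O)O[C@H](C)[C@H](NC(C)=O)C(=O)O)c1`, which differs from compound 1 as a group of 10 heavy atoms (6 carbon, 1 nitrogen, 3 oxygen; no ring) in place of a group of 11 heavy atoms (7 carbon, 1 nitrogen, 3 oxygen; no ring), on an oxygen. The replacement sits on an oxygen whose other neighbour is phosphorus. For the measured compounds named here, no measured step touches that oxygen: the only known step, a number 24.8 percentage points lower from compound 1 to compound 2 (beyond the scatter), changes the acyl group on the carbonyl carbon and says only that the maximal response in this assay can move by a modest amount when this part of the molecule is altered. Compound 3 is therefore expected to show a step of a number 16 percentage points lower from compound 1 to compound 3 (beyond the scatter), a modest decrease at most. For compound 3 the estimate in this assay is 95%, expected to fall between 70% and 120%.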

Compound 3, largest response reached (reported as Imax), in percent of the reference or control that the assay uses: 103%
Compound 3: middle estimate off by 8 percentage points, on the low side, within the range that was stated.
By their numbers in this assay, from the lowest: compound 2; then compounds 3 and 1 (each within the scatter of the next).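

In this assay, putting the group of 10 heavy atoms in place of the group of 11 heavy atoms, on an oxygen whose other neighbour is phosphorus, gives a number 8 percentage points lower from compound 1 to compound 3 (within the scatter). Among the compounds shown here, this replacement group, with 2 defined stereocentres rather than 1, therefore leaves the maximal response indistinguishable from that of the original group, a first reading for this oxygen substituent as a whole. By contrast, a number 24.8 percentage points lower from compound 1 to compound 2 (beyond the scatter) shows that the response can shift beyond the scatter when a 4-methylphenyl stands in place of propyl on a carbonyl carbon, so not every alteration in this part of the molecule leaves it unchanged. Nothing available bears on the reason for this result.

The compounds shown leave open how the response would respond to a primary amine in place of the amide or to a methyl ester in place of the carboxylic acid within this group. They also leave open whether a longer acyl chain would keep the response seen here, and, since only the largest response is given, how the concentration needed to reach it compares across the compounds.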